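A few compounds are considered here, and "the series" means these few. Any claim that something is new, unique, unknown or untested is made for them only; others in the source may bear on it.

Working notes on the series.

Among the compounds with values here, compound 1 `CCc1cccc(Nc2cc(NC(=O)Nc3cc(OC)cc(OC)c3)ncn2)c1` gives 27.7% in a functional assay on NCI-H1581 cells (Homo sapiens) for inhibition, read by MTT assay, with a stated time of 48 h, tested at 10 uM (on this read-out lower numbers stand for less inhibition and higher numbers for more inhibition at the one concentration tested (going by the name of the read-out)), and stands lowest of the three numbers measured so far. Compound 3 `COc1cc(Nc2cc(NC(=O)Nc3c(Cl)cccc3Cl)ncn2)cc(C(F)(F)F)c1` gives 32.3% in this assay, a value within the scatter of compound 1, so no order between the two can be stated. Compound 2 `COc1ccc(C(F)(F)F)cc1Nc1cc(NC(=O)Nc2c(Cl)cccc2Cl)ncn1` gives 69.1% in this assay, which lies beyond the scatter above compound 1. Within the data shown here, none of the measured pairs differ in a single place, so no measured step is available to guide the next case.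

Compound 4 `COc1cc(NC(=O)Nc2cc(Nc3ccc(Br)cc3OC)ncn2)cc(OC)c1` is not yet measured. It differs from compound 1 in one place: 4-bromo-2-methoxyphenyl in place of 3-ethylphenyl on a nitrogen on an aromatic ring. Among the measured compounds shown here, with no measured single step to rest on, only a modest expectation is possible. The change is expected to move the number upward, as a number 12.3 percentage points higher from compound 1 to compound 4 (beyond the scatter), by a step that may or may not exceed the scatter. Compound 4 is expected to give about 40% in this assay, within a range from 20% to 65%.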

Compound 4, a percentage reported as inhibition, at one concentration (the size of the read-out at that concentration, not a potency): 20.1%
Compound 4: the middle estimate sits 19.9 percentage points above what was measured; low and high end bracket the measured number.
By their numbers in this assay, from the lowest: compounds 4, 1 and 3 (each within the scatter of the next, the first and the last beyond it); then compound 2.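

Within the data shown here, the first measured single step falls on a nitrogen on an aromatic ring, where 4-bromo-2-methoxyphenyl in place of 3-ethylphenyl gives a number 7.6 percentage points lower from compound 1 to compound 4 (within the scatter) in this assay. On the core of compound 1, this exchange of one substituted phenyl for another therefore sets no order between the two compounds, even though the entering group carries a hydrogen-bond acceptor that the leaving group lacks. Nothing measured on these compounds bears on the result, so the step stands without an explanation.

Going by these compounds, how the bromine and the methoxy each contribute remains open, as the two enter together in this one step. Also open, on these data alone, is whether an amine-bearing phenyl or a longer alkyl chain on this nitrogen would move the number beyond the scatter.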